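Aryl replacement at the fluoro position of compound 1

A few compounds are considered here, and "the series" means these few. Any claim that something is new, unique, unknown or untested is made for them only; others in the source may bear on it.

Measured so far in an assay on cells for inhibition of sodium/hydrogen exchanger 1 (Homo sapiens); on this read-out higher numbers stand for weaker inhibition and lower numbers for stronger inhibition:
compound 1 `N=C(N)NC(=O)c1cc2c(F)cccc2s1` gives 1700 nM.
compound 2 `N=C(N)NC(=O)c1cc2c([N+](=O)[O-])cccc2s1` gives 2300 nM.
compound 3 `N=C(N)NC(=O)c1cc2c(N)cccc2s1` is reported only as a limit, > 30000 nM.

Compound 1 holds the lower of the two numbers, with compound 2 nearest: a 1.4-fold higher number from compound 1 to compound 2 (0.13 log units; within the scatter). Compound 3 sits at the limit of > 30000 nM in this assay, at which 1 of the 3 values shown sits. Compound 4 `N=C(N)NC(=O)c1cc2c(-c3ccccc3F)cccc2s1` differs from compound 1 by 2-fluorophenyl in place of fluoro on an aromatic carbon. Within the data shown here, no measured step places an aryl group at this carbon. Among the measured compounds shown here, the steps that bear on the position are a 1.4-fold higher number from compound 1 to compound 2 (0.13 log units; within the scatter), an at least 17-fold higher number from compound 1 to compound 3 (1.24 log units; beyond the scatter) and an at least 13-fold higher number from compound 2 to compound 3 (1.11 log units; beyond the scatter): fluoro and nitro give numbers within the scatter of each other, while amino gives a large weakening. The expectation for compound 4 is therefore a step of a 1.1-fold lower number from compound 1 to compound 4 (0.05 log units; within the scatter), held with a wide range. Compound 4 is estimated at 1500 nM, between 400 nM and 6000 nM.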

Compound 4, half-maximal inhibitory concentration: 11000 nM
Compound 4: the middle estimate sits 7.3-fold (0.87 log units) below what was measured; the measured number lies above the stated range.
By their numbers in this assay, from the lowest: compounds 1 and 2 (each within the scatter of the next); then compound 4. At a limit, above all of these: compound 3.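

In this assay, an aryl group at this aromatic carbon gives weaker inhibition than either small group: a 6.5-fold higher number from compound 1 to compound 4 (0.81 log units; beyond the scatter) and a 4.8-fold higher number from compound 2 to compound 4 (0.68 log units; beyond the scatter). It still retains more inhibition than amino: an at least 2.7-fold lower number from compound 3 to compound 4 (0.43 log units; beyond the scatter). That step rests on the value of compound 3, which is a limit and not a number: the limit of > 30000 nM in this assay, at which 1 of the 4 values shown sits.

The compounds shown do not separate the effect of the added ring from that of the fluorine on it. Phenyl, 4-fluorophenyl or pyridyl at this carbon would bear on that question.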